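Hydroxyphenyl imines on a selenazolylmethylthio thiadiazole core

The source may hold more compounds than are shown below. What is called first, only, known or untested is meant among the compounds shown, and "the series" means these compounds.

Measured so far:
compound 1 `Oc1ccccc1/C=N/c1nnc(SCc2c[se]c(-c3ccccc3)n2)s1` gives 15200 nM in a functional assay on MCF7 cells (Homo sapiens) for antiproliferative activity, read by CCK-8 assay; a lower number here means a stronger inhibitor, a higher number a weaker inhibitor
compound 2 `Oc1ccc(/C=N/c2nnc(SCc3c[se]c(-c4ccccc4)n3)s2)cc1` gives 31100 nM

For the measured compounds named here, compound 2 holds the highest of the two numbers in this assay; its nearest neighbour is compound 1, and the step of a 2.0-fold higher number from compound 1 to compound 2 (0.31 log units; beyond the scatter) is the only measured step. Compound 3 `COc1cc(/C=N/c2nnc(SCc3c[se]c(-c4ccccc4)n3)s2)ccc1O` differs from compound 2 by methoxy in place of hydrogen on an aromatic carbon, a methoxy in place of hydrogen on an aromatic carbon. Going by the values given here, no measured step carries a methoxy, so nothing here tells the size or direction of this change; the single known step is modest. Compound 3 is therefore expected near compound 2, with the estimated step of a 1.2-fold lower number from compound 2 to compound 3 (0.08 log units; within the scatter) lying within the scatter. The estimate for compound 3 is 26000 nM, with a range from 10000 nM to 70000 nM.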

Compound 3, half-maximal inhibitory concentration: 15000 nM
Estimate against measurement, compound 3: 1.7-fold (0.24 log units) above, and the stated range covers the measured number.
By their numbers in this assay, from the lowest: compounds 3 and 1 (each within the scatter of the next); then compound 2.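

In this assay, methoxy in place of hydrogen on the aromatic carbon ortho to a hydroxy group gives a 2.1-fold lower number from compound 2 to compound 3 (0.32 log units; beyond the scatter), showing that this ring position responds to substitution and that methoxy here moves the number downward. The 4-hydroxy-3-methoxyphenyl group thus stands level with the 2-hydroxyphenyl group, with a 1.0-fold lower number from compound 1 to compound 3 (0.01 log units; within the scatter). No measurement bearing on the reason for this step is available.

As far as these compounds go, whether the step needs the hydroxy group remains open. So does whether ethoxy or an amine at the same carbon would lower the number further.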